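Shifting the chlorine on compound 3

The compounds below may be only part of what the source reports. "The series", "measured", "known", "first", "only" and "open" are said of these compounds alone.

In a functional assay on K562 cells (Homo sapiens) for antiproliferative activity, read by trypan blue exclusion, with a stated time of 48 h, tested at 10 uM (on this read-out higher numbers stand for more inhibition of growth at the one concentration tested and lower numbers for less inhibition of growth), compound 3 (`NC(=O)c1cc(Br)ccc1NC(=O)/C=C/c1ccccc1Cl`) gives 59%. Compound 1 (`Cc1ccccc1/C=C/C(=O)Nc1ccc(Cl)cc1C(N)=O`) gives 52.2%, which lies within the scatter of compound 3. Compound 2 (`Cc1cccc(/C=C/C(=O)Nc2ccc(Cl)cc2C(N)=O)c1`) gives 37.8%, which is lower than compound 3 by more than the scatter.

Compound 4 (`NC(=O)c1cc(Br)ccc1NC(=O)/C=C/c1ccc(Cl)cc1`) has not yet been measured. It carries 4-chlorophenyl in place of 2-chlorophenyl on a double-bonded chain carbon bound to a double-bonded chain carbon.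

For the measured compounds named here, only one measured step resembles this change. That step is a number 14.4 percentage points lower from compound 1 to compound 2 (beyond the scatter), with 3-methylphenyl in place of 2-methylphenyl at the same place, and it is modest but beyond the scatter. Going by the values given here, it involves a methyl rather than a chlorine, and no measured compound carries 4-chlorophenyl, so it offers only weak guidance. A modest fall in the same direction therefore seems the best guess, and the expected change is a number 12 percentage points lower from compound 3 to compound 4 (beyond the scatter). Compound 4 is estimated at 47%, with an expected range of 30% to 64%.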

Compound 4, percent growth inhibition at one concentration: 22%
Compound 4: middle estimate off by 25 percentage points, on the high side; the whole stated range lies above it.
By their numbers in this assay, from the lowest: compound 4; then compound 2; then compounds 1 and 3 (each within the scatter of the next).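

In this assay, the two groups 2-chlorophenyl and 4-chlorophenyl have the same atoms, yet exchanging one for the other gives a number 37 percentage points lower from compound 3 to compound 4 (beyond the scatter), so the place of the chlorine alone can change growth inhibition by a large amount. For the compounds shown here, the only other step at this place, a number 14.4 percentage points lower from compound 1 to compound 2 (beyond the scatter), also goes down on leaving a 2-substituted phenyl, here 2-methylphenyl, but it involves a different substituent and a different core, so the two pairs suggest a shared trend without establishing one. No measurement available here explains why the place of the chlorine matters so much.

With 3-chlorophenyl and 4-methylphenyl absent from the compounds shown, neither series is complete across the ring. From the compounds shown here alone, it also remains open whether an unsubstituted phenyl or a 2-methoxyphenyl would match compound 3.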